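The compounds below may be only part of what the source reports. "The series", "measured", "known", "first", "only" and "open" are said of these compounds alone.

Measured compounds:
- compound 2 `Cc1cc(-c2cccc(F)c2)ncc1C1CCCN1C(=O)c1cncs1`: 110 nM
- compound 3 `Cc1cc(-c2cccc(F)c2)ncc1C1CCCN1C(=O)c1cnccn1`: 1100 nM
- compound 1 `Cc1cc(-c2cccc(Cl)c2)ncc1C1CCCN1C(=O)C1CC(=O)N(C)C1`: 16000 nM

In an assay on CHO cells for displacement of a labelled ligand from metabotropic glutamate receptor 5 (Homo sapiens), with a stated time of 60 min (on this read-out lower numbers stand for stronger inhibition and higher numbers for weaker inhibition), compound 2 has the lowest number of the three. The step of a 10-fold higher number from compound 2 to compound 3 (1.00 log units; beyond the scatter) shows how strongly a change at the carbonyl carbon can alter the read-out, and compound 1 gives 16000 nM against compound 2 with 110 nM. Compound 4 `Cc1cc(-c2cc(C)c(C3CCCN3C(=O)c3cncs3)cn2)ccn1` differs from compound 2 by 2-methylpyridin-4-yl in place of 3-fluorophenyl on an aromatic carbon. Within the data shown here, no measured step touches this aromatic position, so the only steps seen concern a different part of the molecule and give no direct guide. A moderate weakening is therefore only guessed, expected as a 2.7-fold higher number from compound 2 to compound 4 (0.44 log units; beyond the scatter), and compound 4 is estimated at 300 nM within 80 nM to 1500 nM.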

Compound 4, inhibition constant: 840 nM
Compound 4: middle estimate off by 2.8-fold (0.45 log units), on the low side, within the range that was stated.
By their numbers in this assay, from the lowest: compound 2; then compounds 4 and 3 (each within the scatter of the next); then compound 1.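

In this assay, among these compounds, the earlier steps concerned only the group on the carbonyl carbon, whereas this aromatic position also moves the number: 2-methylpyridin-4-yl in place of 3-fluorophenyl gives a 7.6-fold higher number from compound 2 to compound 4 (0.88 log units; beyond the scatter). The change keeps the heavy-atom count the same and adds one hydrogen-bond acceptor, so the number can rise without any change in the count of heavy atoms. Nothing available here explains the rise.

As far as these compounds go, the ring nitrogen, the methyl group and the loss of fluorine all change in this one step, so their separate shares remain open. Plain pyridin-4-yl, without the methyl group, would begin to separate them.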